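Trifluoromethoxy in place of bromo: note on compound 3

The source may report more compounds than this note shows. Statements on the series, on what has been measured and on what is new or still open speak of the compounds shown alone.

Going by the values given here, compound 2 `Brc1ccc(Cn2cc(CCCOc3cccc4cccnc34)nn2)cc1` gives 29.2 ug/mL in an ADME assay on HaCaT cells (Homo sapiens) for inhibition, read by sulforhodamine B assay, with a stated time of 48 h (a lower number here means a stronger inhibitor of growth, a higher number a weaker inhibitor of growth), the only numerical value shown for the series. Compound 1 `Ic1ccc(Cn2cc(CCCOc3cccc4cccnc34)nn2)cc1` sits at > 250 ug/mL, which is a limit rather than a number. Among the compounds with values here, the one measured step, an at least 8.5-fold lower number from compound 1 to compound 2 (0.93 log units; beyond the scatter), starts from the limit of > 250 ug/mL in this assay, at which 1 of the 2 values shown sits, and is therefore itself only a bound. Compound 3 `FC(F)(F)Oc1ccc(Cn2cc(CCCOc3cccc4cccnc34)nn2)cc1` differs from compound 2 by trifluoromethoxy in place of bromo on an aromatic carbon. Within the data shown here, no measured step involves trifluoromethoxy, and the halogen step gives no guidance on it, so the expected step is a 1.4-fold higher number from compound 2 to compound 3 (0.14 log units; within the scatter), within the scatter. For compound 3 the estimate in this assay is 40 ug/mL, ranging 12 ug/mL to 150 ug/mL.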

Compound 3, concentration for 50% growth inhibition: 4 ug/mL
Compound 3: the middle estimate sits 10-fold (1.00 log units) above what was measured, outside the stated range (below it).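

At this position on the aromatic ring, the number in this assay responds to a group other than a halogen: trifluoromethoxy in place of bromo gives a 7.3-fold lower number from compound 2 to compound 3 (0.86 log units; beyond the scatter) and so extends the range seen with the two halogens. Compound 3 now carries the lowest number of the three, with its steps from both others beyond the scatter. The step of an at least 62-fold lower number from compound 1 to compound 3 (1.79 log units; beyond the scatter) is only a bound, as it starts from a limit: the limit of > 250 ug/mL in this assay, at which 1 of the 3 values shown sits.

As far as these compounds go, how an amine, a carboxylic acid or a chloro group would read at this position remains open. The shared core and the propyl-length chain are constant across all three compounds, so their contribution cannot be judged.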